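The source may hold more compounds than are shown below. What is called first, only, known or untested is meant among the compounds shown, and "the series" means these compounds.

Measured in a functional assay on MOLT-4 cells (Homo sapiens) for inhibition; on this read-out lower numbers stand for stronger inhibition and higher numbers for weaker inhibition:
Compound 1 `O=C1CCCCC/C1=C\c1ccc(F)cc1`: 250000 nM
Compound 2 `Cc1ccc(/C=C2\CCCCCC2=O)cc1`: > 500000 nM, a limit of the assay

For compound 2 the assay gives only a limit and not a number: the limit of > 500000 nM in this assay, at which 1 of the 2 values shown sits. Compound 3 `COc1ccc(/C=C2\CCCCCC2=O)cc1` differs from compound 2 on an aromatic carbon of a six-membered aromatic ring of carbon only, para to a group of 9 heavy atoms, with methoxy in place of methyl on an aromatic carbon. Among the compounds with values here, the only measured step, an at least 2.0-fold higher number from compound 1 to compound 2 (0.30 log units; that floor lies within the scatter), is a different exchange, methyl in place of fluoro on an aromatic carbon, and its size is known only as a floor. Resting on an at least 2.0-fold higher number from compound 1 to compound 2 (0.30 log units; that floor lies within the scatter), no step beyond the scatter is expected in this assay. The expected step is an at least 1.2-fold lower number from compound 2 to compound 3 (0.09 log units; that floor lies within the scatter). A report of only a limit would be no surprise. The estimate for compound 3 is 400000 nM, with an expected range of 150000 nM to 800000 nM.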

Compound 3, half-maximal inhibitory concentration: 250000 nM
Compound 3: middle estimate off by 1.6-fold (0.20 log units), on the high side; the range from low to high includes it.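

In this assay, putting methoxy in place of methyl on this aromatic carbon, para to a group of 9 heavy atoms, gives an at least 2.0-fold lower number from compound 2 to compound 3 (0.30 log units; that floor lies within the scatter). Compound 2 carries a limit and not a number, so this step is known only as a floor: the limit of > 500000 nM in this assay, at which 1 of the 3 values shown sits.

Set against fluoro at the same position, methoxy gives no change at the digits printed from compound 1 to compound 3 (within the scatter), so the assay does not separate these two groups.

On these data alone, how far compound 2 truly lies from compound 3 stays open, and none of the steps among the three groups at this position is printed as beyond the scatter. As far as these compounds go, whether an amine or a carboxylic acid on this aromatic carbon would move the number beyond the scatter also remains open.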